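Toward compound 4: adding methoxy and methylating the amide

The source may hold more compounds than are shown below. What is called first, only, known or untested is meant among the compounds shown, and "the series" means these compounds.

Three close relatives of one core have been examined in a functional assay on CHO cells for agonist activity at Orexin/Hypocretin receptor type 1 (Homo sapiens); on this read-out lower numbers stand for smaller maximal responses and higher numbers for larger maximal responses. Compound 1 `COc1ccc(-c2cccc(C(=O)N(C)C)c2)cc1S(=O)(=O)Nc1ccc2ccc(NC(=O)c3ccccc3)cc2c1` has no reported number in this assay, recorded as "nd" (no result reported). Compound 2 `COc1ccc(-c2cccc(C(=O)N(C)C)c2)cc1S(=O)(=O)Nc1ccc2cccc(NC(=O)c3ccccc3)c2c1` gives 31.8%, the lowest of the two numbers available, with compound 3 as its nearest neighbour. Among the compounds with values here, compound 3 `COc1cccc(C(=O)Nc2cccc3ccc(NS(=O)(=O)c4cc(-c5cccc(C(=O)N(C)C)c5)ccc4OC)cc23)c1` reaches 107%, and the single step between them, a number 75.2 percentage points higher from compound 2 to compound 3 (beyond the scatter), came with methoxy in place of hydrogen on an aromatic carbon.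

Compound 4 `COc1cccc(C(=O)N(C)c2cccc3ccc(NS(=O)(=O)c4cc(-c5cccc(C(=O)N(C)C)c5)ccc4OC)cc23)c1` has not yet been measured. Relative to compound 2 the change is ((3-methoxyphenyl)carbonyl)(methyl)amino in place of benzamido on an aromatic carbon. Part of this change repeats what separates compound 2 from compound 3, namely the methoxy on the benzamide ring, and that step was large and beyond the scatter. The other part, the methyl on the amide nitrogen, has no measured counterpart among these compounds, so its effect is unknown.

Because the shared portion of the change produced a number 75.2 percentage points higher from compound 2 to compound 3 (beyond the scatter), the expected direction is upward, likely by a large margin, though the unmeasured methylation widens the uncertainty. The estimated step is a number 53.2 percentage points higher from compound 2 to compound 4 (beyond the scatter). Compound 4 is therefore expected to give about 85%, within a range from 40% to 115%.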

Compound 4, largest response reached (Emax), in percent of the reference or control that the assay uses: 101%
The estimate for compound 4 lay 16 percentage points below the measured number; measured number inside the range.
By their numbers in this assay, from the lowest: compound 2; then compounds 4 and 3 (each within the scatter of the next).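

In this assay, the new information concerns the methyl on the amide nitrogen, which gives a number 6 percentage points lower from compound 3 to compound 4 (within the scatter); the amide hydrogen can therefore be replaced by methyl with no readable change in the maximal response, even though the entering group has lost the hydrogen-bond donor that benzamido carried. The full replacement of benzamido by ((3-methoxyphenyl)carbonyl)(methyl)amino gives a number 69.2 percentage points higher from compound 2 to compound 4 (beyond the scatter), so the large gain that came with the methoxy on the benzamide ring persists when the amide nitrogen also carries methyl. Nothing available here explains why the response shifts with the methoxy or stays put with the methyl.

On these data alone, what the methyl does on its own, on a benzamide ring without the methoxy, remains open, so these compounds cannot show whether its silence depends on the methoxy being present. As far as these compounds go, it is also open whether the amide nitrogen would accept something larger than methyl, such as an ethyl group or a longer chain, and whether an amine or a carboxylic acid could take the place of the methoxy on that ring and keep the response.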